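Aryl swap in a series held at the assay limit

A few compounds are considered here, and "the series" means these few. Any claim that something is new, unique, unknown or untested is made for them only; others in the source may bear on it.

Compound 3 `COc1cc(-n2ncnc2-c2cccc(Cl)c2)cc(OC)c1OC` gives > 10000 nM in a functional assay on Jurkat cells (Homo sapiens) for antiproliferative activity, read by MTT assay, with a stated time of 72 h (a lower number here means a stronger inhibitor, a higher number a weaker inhibitor), as a limit and not a number. Compound 1 `COc1cccc(-c2ncnn2-c2cc(OC)c(OC)c(OC)c2)c1` gives > 10000 nM as a limit as well. Compound 2 `COc1cc(-n2ncnc2-c2ccc(Cl)c(Cl)c2)cc(OC)c1OC` gives > 10000 nM as a limit too. The set so far therefore rests on the limit of > 10000 nM in this assay, at which 3 of the 3 values shown sit, and holds no numerical value.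

Compound 4 `COc1ccccc1-c1ncnn1-c1cc(OC)c(OC)c(OC)c1` differs from compound 3 by 2-methoxyphenyl in place of 3-chlorophenyl on an aromatic carbon with 2-methoxyphenyl in place of 3-chlorophenyl on an aromatic carbon. The measured steps that bear on this change are a step that the two limits leave unreadable from compound 1 to compound 3 and a step that the two limits leave unreadable from compound 2 to compound 3 and also a step that the two limits leave unreadable from compound 1 to compound 2 so none supplies a size. No change of this aryl group has yet given a compound a value off the limit. Compound 4 is expected to stay weak, most likely reported as a limit again. The expected step is a step that the limit leaves unreadable from compound 3 to compound 4 in this assay with no shift beyond the scatter anticipated. For compound 4 the estimate is 12000 nM with an expected range from 3000 nM to 40000 nM for a measured number.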

Compound 4, half-maximal inhibitory concentration: > 10000 nM
Compound 4: a limit, no number; the forecaster's own chance of this, stated with the estimate: 85%; the middle value lies beyond the limit too.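

The steps from compound 1, compound 2 and compound 3 to compound 4 cannot be read in this assay, and the series still holds no number: the limit of > 10000 nM in this assay, at which 4 of the 4 values shown sit.

The compounds shown leave open whether any aryl group on the shared core gives a value off this limit, and how large such a step would be.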